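The source may report more compounds than this note shows. Statements on the series, on what has been measured and on what is new or still open speak of the compounds shown alone.

Compound 1, `CC(C)[C@H](c1ccc(C(=O)NCc2nn[nH]n2)cc1)N1C(=O)C(c2cc(Cl)cc(Cl)c2)=N[C@]12CC[C@@H](C(C)(C)C)CC2`: 2200 nM
Compound 2, `CC(C)(C)CC[C@H](c1ccc(C(=O)NCc2nn[nH]n2)cc1)N1C(=O)C(c2cccc(C(F)(F)F)c2)=N[C@]12CC[C@@H](C(C)(C)C)CC2`: 180 nM

Both compounds were tested in a functional assay on CHO cells for antagonist activity at Glucagon receptor (Homo sapiens), read by cAMP accumulation, with stated times of 30 min and 45 min; on this read-out higher numbers stand for weaker inhibition and lower numbers for stronger inhibition. Compound 1 gives 2200 nM, the highest of the two numbers; compound 2 gives 180 nM, clearly lower, but compound 2 differs from compound 1 both in the chain on the carbon next to the ring nitrogen and in the aryl group, so no single step can be read from the pair. Compound 3, `CCCCC[C@H](c1ccc(C(=O)NCc2nn[nH]n2)cc1)N1C(=O)C(c2cc(Cl)cc(Cl)c2)=N[C@]12CC[C@@H](C(C)(C)C)CC2`, has not yet been measured. It differs from compound 1 by pentyl in place of isopropyl on a saturated chain carbon bound to an amide-type nitrogen in a ring and an aromatic carbon. The comparison of compound 1 with compound 2 shows a longer chain at that carbon going together with a lower number, though the aryl change shares in that. The step of a 3.1-fold lower number from compound 1 to compound 3 (0.50 log units; beyond the scatter) is therefore expected to move toward a lower number, probably beyond the scatter. Compound 3 is estimated at 700 nM, within 200 nM to 2500 nM.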

Compound 3, half-maximal inhibitory concentration: 130 nM
Beside the measured number, compound 3's estimate is 5.4-fold (0.73 log units) above it; the whole stated range lies above it.
By their numbers in this assay, from the lowest: compounds 3 and 2 (each within the scatter of the next); then compound 1.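

Changing isopropyl to pentyl, with nothing else altered, gives a 17-fold lower number from compound 1 to compound 3 (1.23 log units; beyond the scatter) in this assay and so shows that the chain at this carbon alone can move the number by a large amount. The earlier pair changed the chain and the aryl group together, so it could not separate the two; here the aryl group of compound 1 stays in place and the step belongs to the chain. No measurement among those shown explains this step.

As far as these compounds go, with only these two chains compared on this aryl group, it stays open whether a longer chain such as heptyl would lower the number further, or whether a cyclohexyl ring or a chain ending in a carboxylic acid would be tolerated at this carbon. From the compounds shown here alone, whether pentyl would give a similar step alongside the aryl group of compound 2 also remains open.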